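Clearance notes on a shared core: compounds 1, 2 and 3

The compounds below may be only part of what the source reports. "The series", "measured", "known", "first", "only" and "open" are said of these compounds alone.

Measured so far:
- compound 1 `CCCCCOC(=O)N1CCN(C(=O)[C@H](CCC(=O)O)NC(=O)c2cc(N3CCC(C(=O)N(CC)CC)CC3)nc(-c3ccccc3)n2)CC1` in an in vivo ADME assay on the whole organism (strain Sprague-Dawley) for pharmacokinetics, with Rattus norvegicus as the target; on this read-out higher numbers stand for fast clearance and lower numbers for slow clearance — compound 1 gives 6 mL/min/kg
- compound 2 `CCCCCOC(=O)N1CCN(C(=O)[C@H](CCC(=O)O)NC(=O)c2nc(-c3ccccc3)cc(N3CCC(COC)CC3)n2)CC1` in this assay — compound 2 gives 6 mL/min/kg

Compound 1 stands level with compound 2 in this assay at the digits shown; the two values lie within the scatter of each other, so nothing can be read from the gap between them. Among the compounds with values here, no pair differing in one place has been measured, so no measured step is available as a guide.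

Compound 3 `CCCCCOC(=O)N1CCN(C(=O)[C@H](CCC(=O)O)NC(=O)c2cc(N3CCC(C(N)=O)CC3)nc(-c3ccccc3)n2)CC1` has not yet been measured in this assay. It departs from compound 1 in one place: amino in place of diethylamino on a carbonyl carbon, the neighbour of that carbon being a saturated ring carbon. Nothing in the measured set speaks for a move in either direction; the expected step in this assay is no change at the digits printed from compound 1 to compound 3 (within the scatter), none beyond the scatter. Compound 3 is therefore expected to give 6 mL/min/kg in this assay, with an estimated range from 3 mL/min/kg to 13 mL/min/kg.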

Compound 3, clearance: 68 mL/min/kg
Compound 3: middle estimate off by 11-fold (1.05 log units), on the low side; the whole stated range lies below it.
By their numbers in this assay, from the lowest: compounds 1 and 2 (each within the scatter of the next); then compound 3.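

In this assay the carbonyl carbon on the saturated ring carbon emerges as a place where clearance depends strongly on the attached group: amino in place of diethylamino gives an 11-fold higher number from compound 1 to compound 3 (1.05 log units; beyond the scatter) with the rest of the molecule unchanged. Within the data shown here, this is the first measured single-place step, so it shows that the diethylcarbamoyl to carbamoyl change can move clearance well beyond the scatter, and it sets the direction of that move for this pair. The change removes the carbon-bearing diethylamino group and brings in a hydrogen-bond donor, but no measurement at hand links the step to either feature or gives a reason for it.

On these data alone, with one step at this position, it remains open whether clearance rises gradually or abruptly on going from diethylamino to amino, and whether ethylamino or dimethylamino would give a value closer to compound 1 or to compound 3. Also open, as far as these compounds go, is how the position behaves without the amide, for example with a nitrile or a carboxylic acid on the saturated ring carbon.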